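The compounds below may be only part of what the source reports. "The series", "measured", "known", "first", "only" and "open" are said of these compounds alone.

Compound 3 `Cn1nnnc1SCC(=O)N/N=c1/scc(-c2ccc([N+](=O)[O-])cc2)n1-c1ccccc1` carries a nitro group on one of its phenyl rings, and in an ADME assay on NIH3T3 cells (Mus musculus) for cytotoxicity, read by MTT assay, with a stated time of 24 h (on this read-out lower numbers stand for stronger inhibition and higher numbers for weaker inhibition), compound 3 gives 167 ug/mL. Two related compounds were tested alongside it: compound 1 `Cn1nnnc1SCC(=O)N/N=c1/scc(-c2ccc(F)cc2)n1-c1ccccc1`, which in this assay gives 113 ug/mL, and compound 2 `O=C(CSc1ncccn1)N/N=c1/scc(-c2ccccc2)n1-c1ccccc1`, which in this assay gives 107 ug/mL. Both of those numbers sit within the usual scatter of the value of compound 3. Among the compounds with values here, the one directly comparable step among them is a 1.5-fold higher number from compound 1 to compound 3 (0.17 log units; within the scatter), which did not move the number beyond the scatter. Compound 4 `Cn1nnnc1SCC(=O)N/N=c1/scc(-c2ccccc2)n1-c1ccccc1` differs from compound 3 by hydrogen in place of nitro on an aromatic carbon. Within the data shown here, since the only swap at this position made no difference beyond the scatter, compound 4 is expected to show a 1.5-fold lower number from compound 3 to compound 4 (0.16 log units; within the scatter) in this assay, giving an estimated 115 ug/mL, between 60 ug/mL and 220 ug/mL.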

Compound 4, half-maximal inhibitory concentration: 173 ug/mL
The estimate for compound 4 lay 1.5-fold (0.18 log units) below the measured number, within the range that was stated.
By their numbers in this assay, from the lowest: compounds 2, 1, 3 and 4 (each within the scatter of the next).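

In this assay, hydrogen in place of the substituent on the aromatic carbon leaves the number within the scatter, with a 1.0-fold higher number from compound 3 to compound 4 (0.02 log units; within the scatter) and a 1.5-fold higher number from compound 1 to compound 4 (0.18 log units; within the scatter), so nitro, fluoro and hydrogen now all read alike at this position. A second place gives the same picture: 1-methyl-1H-tetrazol-5-yl in place of pyrimidin-2-yl on the sulfur gives a 1.6-fold higher number from compound 2 to compound 4 (0.21 log units; within the scatter). No measured evidence here bears on why these numbers stay so close.

From the compounds shown here alone, whether an amine or a carboxylic acid at this position would move the number beyond the scatter remains open.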